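Pyridyl vinyl sulfones: ring attachment and Nrf2 activation

This account rests on a few compounds, and the source may have more. Where it says the series, first, only, none or still open, it means among the compounds named here.

Compound 1 `COc1ccccc1S(=O)(=O)/C=C/c1cccnc1` and compound 2 `COc1ccc(S(=O)(=O)/C=C/c2cccnc2)cc1` are both measured in an assay on U2OS cells for activation of nuclear factor erythroid 2-related factor 2 (Homo sapiens), read by chemiluminescence, with a stated time of 6 h; on this read-out lower numbers stand for an effect already at smaller amounts and higher numbers for an effect only at larger amounts of compound. Compound 1 gives only a limit of the assay, > 10000 nM. Compound 2 likewise gives only a limit, > 10000 nM. Compound 3 `COc1ccccc1S(=O)(=O)/C=C/c1ccncc1` differs from compound 1 by pyridin-4-yl in place of pyridin-3-yl on a double-bonded chain carbon bound to a double-bonded chain carbon. In this assay compound 3 gives 1520 nM, a step of an at least 6.5-fold lower number from compound 1 to compound 3 (0.81 log units; beyond the scatter); the size is bounded because of the limit of > 10000 nM in this assay, at which 2 of the 3 values shown sit. The difference between the cores of compound 1 and compound 2 is not broken down here. Compound 4 `COc1ccc(S(=O)(=O)/C=C/c2ccncc2)cc1`, not yet measured, differs from compound 2 by pyridin-4-yl in place of pyridin-3-yl on a double-bonded chain carbon bound to a double-bonded chain carbon, the same change. Compound 4 is expected to move by an at least 3.3-fold lower number from compound 2 to compound 4 (0.52 log units; beyond the scatter) in this assay, since from compound 1 the same change gave an at least 6.5-fold lower number from compound 1 to compound 3 (0.81 log units; beyond the scatter). Compound 4 is therefore estimated at 3000 nM, with a range from 800 nM to 12000 nM.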

Compound 4, half-maximal effective concentration: 1200 nM
Estimate against measurement, compound 4: 2.5-fold (0.40 log units) above; the measured number falls inside the stated range.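

In this assay the change to pyridin-4-yl from pyridin-3-yl carries over to a second core, with an at least 8.3-fold lower number from compound 2 to compound 4 (0.92 log units; beyond the scatter) on the core of compound 2. Set beside the earlier step, the two compare as follows: the same change on two cores in this assay, an at least 6.5-fold lower number (0.81 log units; beyond the scatter) from compound 1 to compound 3 and an at least 8.3-fold lower number (0.92 log units; beyond the scatter) from compound 2 to compound 4; the limit leaves it open whether they differ. The direction of the change is therefore the same on both cores shown, but no size can be assigned to either step, and no transfer beyond these two cores is shown, as both steps start from an assay limit: the limit of > 10000 nM in this assay, at which 2 of the 4 values shown sit.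

Still open, from the compounds shown here alone, is how pyridin-2-yl would compare at the same place on the chain. Also open, going by these compounds, is whether the change holds when an amine or a carboxylic acid replaces the methoxy group.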